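The source may hold more compounds than are shown below. What is called first, only, known or untested is meant among the compounds shown, and "the series" means these compounds.

Working notes on the series, with measurements in an ADME assay on microsomes from liver (Canis lupus familiaris) for metabolic stability, read by LC-MS, using NADPH, with a stated time of 10 min, tested at 0.1 uM (a higher number here means faster removal of the compound, a lower number slower removal), as follows.

- compound 1 `COc1ccc(F)cc1N1C(=O)CSC1c1cccc(C(=O)NCCCCc2ccccc2)c1` gives 1650 mL.min-1.g-1
- compound 2 `Cc1cccc(N2C(=O)CSC2c2cccc(C(=O)NCCCCc3ccccc3)c2)c1` gives 749 mL.min-1.g-1
- compound 3 `O=C(NCCCCc1ccccc1)c1cccc(C2SCC(=O)N2c2cccc(-c3c[nH]nn3)c2)c1` gives 226 mL.min-1.g-1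

Compound 3 has the lowest number of the three, and both gaps to it lie beyond the scatter: a 3.3-fold lower number from compound 2 to compound 3 (0.52 log units; beyond the scatter) and a 7.3-fold lower number from compound 1 to compound 3 (0.86 log units; beyond the scatter) in this assay terms.

The next compound is compound 4 `O=C(NCCCCc1ccccc1)c1cccc(C2SCC(=O)N2c2ccccn2)c1`, which differs from compound 3 as follows: a group of 6 heavy atoms (5 carbon, 1 nitrogen; one six-membered aromatic ring with 1 hetero atom) in place of a group of 11 heavy atoms (8 carbon, 3 nitrogen; one five-membered aromatic ring with 3 hetero atoms, one six-membered aromatic ring of carbon only), on an amide-type nitrogen in a ring. Among the measured compounds shown here, the pyridin-2-yl group appears in no measured compound, so no direct precedent exists. All three measured steps nevertheless concern the group on the same ring nitrogen, and a 2.2-fold lower number from compound 1 to compound 2 (0.34 log units; beyond the scatter) shows that the number moves there even without the triazole. The most relevant step is a 3.3-fold lower number from compound 2 to compound 3 (0.52 log units; beyond the scatter), which added the 1H-1,2,3-triazol-4-yl group, and compound 4 no longer carries that group. Part of that drop is therefore expected to be lost, though the three compounds offer only a thin basis. The expected change is a 2.0-fold higher number from compound 3 to compound 4 (0.30 log units; within the scatter), an upward step of modest size and an uncertain one. For compound 4 the estimated value is 450 mL.min-1.g-1, with an expected range from 180 mL.min-1.g-1 to 1100 mL.min-1.g-1 in this assay terms.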

Compound 4, intrinsic clearance in microsomes: 492 mL.min-1.g-1
Compound 4: the middle estimate sits 1.1-fold (0.04 log units) below what was measured; low and high end bracket the measured number.
By their numbers in this assay, from the lowest: compound 3; then compounds 4 and 2 (each within the scatter of the next); then compound 1.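

Exchanging the whole group on the amide-type nitrogen for pyridin-2-yl gives in this assay the step (a 2.2-fold higher number from compound 3 to compound 4 (0.34 log units; beyond the scatter)), so the number of compound 3 does not carry over to a single ring with 1 hetero atom and no 1H-1,2,3-triazol-4-yl group. Set against the 3-methylphenyl group, the same pyridin-2-yl group gives (a 1.5-fold lower number from compound 2 to compound 4 (0.18 log units; within the scatter)), so compound 2 and compound 4 cannot be told apart here, and a ring nitrogen in the group at this position shows no separate step from a methyl-bearing phenyl ring. Set against the 5-fluoro-2-methoxyphenyl group, it gives (a 3.4-fold lower number from compound 1 to compound 4 (0.53 log units; beyond the scatter)), which leaves compound 1 with the highest number of the four, apart from every other compound, and compound 3 with the lowest.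

No supporting data bear on why the number moves at this position.

From the compounds shown here alone, it remains open whether the low number of compound 3 belongs to the triazole ring itself or would also follow from a carboxylic acid or an amine in place of the 1H-1,2,3-triazol-4-yl group.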